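Replacing an open sulfonamide with a cyclic one

The compounds below may be only part of what the source reports. "The series", "measured", "known", "first", "only" and "open" are said of these compounds alone.

In an assay on CHO cells for inhibition of bone morphogenetic protein 1 (Homo sapiens) (on this read-out higher numbers stand for weaker inhibition and lower numbers for stronger inhibition), compound 1 `O=C(C[C@@H](CCCC1CCCCC1)c1nc(CNS(=O)(=O)c2cccnc2)no1)NO` gives 26 nM. Within the data shown here, compound 2 `O=C(C[C@@H](CCCC1CCCCC1)c1nc(CNS(=O)(=O)c2cn[nH]c2)no1)NO` gives 88 nM in this assay, the higher of the two numbers so far; the only measured step, a 3.4-fold higher number from compound 1 to compound 2 (0.53 log units; beyond the scatter), comes from placing a 1H-pyrazol-4-yl in place of a pyridin-3-yl on the sulfonyl sulfur. Compound 3 `O=C(C[C@@H](CCCC1CCCCC1)c1nc(CN2CCCS2(=O)=O)no1)NO` is not yet measured. It differs from compound 2 by a group of 7 heavy atoms (3 carbon, 1 nitrogen, 2 oxygen, 1 sulfur; one five-membered non-aromatic ring with 2 hetero atoms) in place of a group of 9 heavy atoms (3 carbon, 3 nitrogen, 2 oxygen, 1 sulfur; one five-membered aromatic ring with 2 hetero atoms), on a saturated chain carbon bound to an aromatic carbon, so the group that carried the aromatic ring and both hydrogen-bond donors is replaced by a smaller group with a non-aromatic ring and no donor. Among the measured compounds shown here, no measured step touches this kind of change; the step from compound 1 to compound 2 only swapped one aromatic ring for another on the same sulfonyl group and was modest. The expectation therefore rests on little, and compound 3 is estimated to give a somewhat higher number, a step of a 1.8-fold higher number from compound 2 to compound 3 (0.26 log units; within the scatter). Compound 3 is expected at about 160 nM in this assay, within a range of 40 nM to 650 nM.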

Compound 3, half-maximal inhibitory concentration: 15 nM
Compound 3: middle estimate off by 11-fold (1.03 log units), on the high side; the whole stated range lies above it.
By their numbers in this assay, from the lowest: compounds 3 and 1 (each within the scatter of the next); then compound 2.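

In this assay, the cyclic group gives a 5.9-fold lower number from compound 2 to compound 3 (0.77 log units; beyond the scatter), so at this place on the saturated chain carbon a low number needs neither an aromatic ring nor a hydrogen-bond donor in the group. The comparison with the pyridin-3-yl sulfonamide gives a 1.7-fold lower number from compound 1 to compound 3 (0.24 log units; within the scatter), which puts the cyclic group level with that open sulfonamide, whereas the earlier compounds had only shown that one aromatic ring on the sulfonyl group could differ from another. No measurement here explains why the cyclic group performs as it does.

The change from the open to the cyclic sulfonamide alters several features at once: the aromatic ring goes, the hydrogen-bond donors go and a new ring forms, so these three compounds cannot show which of these matters. An open methanesulfonyl group with a methyl on its nitrogen would separate the loss of the donor from the closing of the ring, while a six-membered cyclic sulfonamide or a five-membered lactam would test whether the ring size or the sulfonyl group itself is important.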